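The source may hold more compounds than are shown below. What is called first, only, known or untested is meant among the compounds shown, and "the series" means these compounds.

Working notes on the series, all read in a functional assay (strain AB) with Danio rerio as the target, read by microscopy, with a stated time of 1 h; on this read-out higher numbers stand for an effect only at larger amounts of compound and lower numbers for an effect already at smaller amounts. Compound 1 `CCC1CCc2c(sc(NC(=O)Nc3ccc(Cl)cc3)c2C(N)=O)C1` gives > 25000 nM, which is a limit of the assay and not a number. Compound 2 `CCN1CCc2c(sc(NC(=O)Nc3ccc4ccccc4c3)c2C(N)=O)C1` gives 1780 nM, and compound 3 `NC(=O)c1c(NC(=O)Nc2ccc(Cl)cc2)sc2c1CCN(C1CCOCC1)C2` gives 2830 nM. These two numbers, the only ones available in this assay, lie within the scatter of each other, so compound 3 stands level with compound 2.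

Next is compound 4 `COCCCN1CCc2c(sc(NC(=O)Nc3ccc(Cl)cc3)c2C(N)=O)C1`, which carries 3-methoxypropyl in place of oxan-4-yl on an amine nitrogen in a ring. Among the measured compounds shown here, no measured pair differs in one place only, so the data give no direct guide to this change. The expectation in this assay therefore rests on compound 3 at 2830 nM, with no step beyond the scatter in either direction. The expected change is small, an estimated step of a 1.1-fold higher number from compound 3 to compound 4 (0.03 log units; within the scatter). The range is kept wide, as the series is so small. For compound 4 the estimated value is 3000 nM, with an expected range of 1200 nM to 9000 nM.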

Compound 4, half-maximal effective concentration: 2400 nM
For compound 4 the middle estimate is 1.3-fold (0.10 log units) above the measured one; the measured number falls inside the stated range.
By their numbers in this assay, from the lowest: compounds 2, 4 and 3 (each within the scatter of the next). At a limit, above all of these: compound 1.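

Among the compounds shown here, the step of a 1.2-fold lower number from compound 3 to compound 4 (0.07 log units; within the scatter) is the first comparison that differs in one place only, and it is read in this assay. At the amine nitrogen in a ring, exchanging the oxan-4-yl ring for the open 3-methoxypropyl chain, with 5 heavy atoms in place of 6 and still 1 hydrogen-bond acceptor and no net charge, therefore leaves the read-out unchanged within the scatter. No measurement at hand bears on a cause for this outcome.

From the compounds shown here alone, whether a carboxylic acid or a second amine on this nitrogen would keep the number at this level remains open. Going by these compounds, it is also open whether a longer chain ending in a methoxy group, with the rest of compound 4 kept, would do the same.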